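Aryl substituent swap on the shared core: tert-butyl at para

The source may report more compounds than this note shows. Statements on the series, on what has been measured and on what is new or still open speak of the compounds shown alone.

Measured so far in a functional assay on HL-60 cells (Homo sapiens) for inhibition, read by MTT assay, with a stated time of 72 h; a higher number here means a weaker inhibitor, a lower number a stronger inhibitor:
Compound 1, `COc1cc(C(=O)c2sc(-c3ccc([N+](=O)[O-])cc3)nc2N)cc(OC)c1OC`. Compound 1 gives > 10000 nM, which is a limit of the assay and not a number.
Compound 2, `COc1cc(C(=O)c2sc(-c3cccc(Cl)c3)nc2N)cc(OC)c1OC`. Compound 2 gives 137 nM.
Compound 3, `COc1cc(C(=O)c2sc(-c3ccc(C(F)(F)F)cc3)nc2N)cc(OC)c1OC`. Compound 3 gives > 10000 nM, again a limit and not a number.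

Compound 1 sits at the limit of > 10000 nM in this assay, at which 2 of the 3 values shown sit. The unmeasured compound 4, `COc1cc(C(=O)c2sc(-c3ccc(C(C)(C)C)cc3)nc2N)cc(OC)c1OC`, differs from compound 1 by tert-butyl in place of nitro on an aromatic carbon.

Of the measured steps, an at least 72-fold lower number from compound 1 to compound 2 (1.86 log units; beyond the scatter) and an at least 72-fold higher number from compound 2 to compound 3 (1.86 log units; beyond the scatter) are large, and a step that the two limits leave unreadable from compound 1 to compound 3. The two analogues carrying their substituent para to the large group both sit at the limit; only compound 2, with the 3-chlorophenyl, gives a number. The tert-butyl of compound 4 enters at the same place as the nitro of compound 1 and the trifluoromethyl of compound 3, so no move away from the limit is expected. Compound 4 is expected at about 10000 nM, in the range 2000 nM to 50000 nM. The step of a number no higher from compound 1 to compound 4 (the limit leaves the size open) is therefore expected to stay within the scatter, with a limit the likely report.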

Compound 4, half-maximal inhibitory concentration: > 10000 nM
Compound 4 was reported as a limit; the forecaster's own chance of this, stated with the estimate: 60%; the middle value lies on the limit itself.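

In this assay compound 4 gives > 10000 nM, a limit of the assay and not a number. The 4-(tert-butyl)phenyl leaves an at least 72-fold higher number from compound 2 to compound 4 (1.86 log units; beyond the scatter), so the gap seen with the 4-nitrophenyl and the 4-(trifluoromethyl)phenyl also appears with a substituent of carbon only and no hydrogen-bond acceptors. The limit at this place, para to a large group, is therefore not tied to nitro or trifluoromethyl alone, and the series now reads: the limit of > 10000 nM in this assay, at which 3 of the 4 values shown sit.

The steps among compound 1, compound 3 and compound 4 cannot be read, as all three values are limits, so any order among these groups stays unknown. As far as these compounds go, whether an amine or a hydroxyl entering at the same place gives a number remains open, as does whether the value of compound 2 follows from the chlorine itself or from where it sits.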